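The compounds below may be only part of what the source reports. "The series", "measured", "known", "first", "only" and "open" are said of these compounds alone.

Working notes on the series, read in a functional assay on a cell-free system (plasma, Homo sapiens) for inhibition, with Plasma (Rattus norvegicus) as the target; a higher number here means a weaker inhibitor, a lower number a stronger inhibitor. Three compounds on the shared core differ only in the group on a saturated chain carbon bound to an oxygen on an aromatic ring. Compound 1 (`Cc1c(OCc2cccnc2)ccc2c(N3CCNCC3)cc(=O)oc12`) gives 1420 nM, compound 2 (`COc1c(C)cnc(COc2ccc3c(N4CCNCC4)cc(=O)oc3c2C)c1C`) gives 5800 nM and compound 3 (`COCOc1ccc2c(N3CCNCC3)cc(=O)oc2c1C`) gives 3500 nM. Compound 3 therefore sits at the upper end of the three numbers, level with compound 2. The two steps that reach it are a 1.7-fold lower number from compound 2 to compound 3 (0.22 log units; within the scatter) and a 2.5-fold higher number from compound 1 to compound 3 (0.39 log units; beyond the scatter).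

Compound 4 (`Cc1c(OCC2CCCN(C)C2)ccc2c(N3CCNCC3)cc(=O)oc12`) carries 1-methylpiperidin-3-yl in place of the methoxy of compound 3 at that place: 1-methylpiperidin-3-yl in place of methoxy on a saturated chain carbon bound to an oxygen on an aromatic ring. Among the measured compounds shown here, no measured compound has a non-aromatic ring here, so the evidence is indirect. The closest guide is the exchange of methoxy against the two pyridinyl groups, which gave the two steps above, one modest and one within the scatter. Between those two groups the step is a 4.1-fold higher number from compound 1 to compound 2 (0.61 log units; beyond the scatter). Steps at this place have so far stayed modest, and they give no firm direction. The expected step is therefore small, a 1.4-fold lower number from compound 3 to compound 4 (0.15 log units; within the scatter). For compound 4 the estimated value is 2500 nM, with an expected range of 900 nM to 7000 nM.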

Compound 4, half-maximal inhibitory concentration: 16400 nM
The estimate for compound 4 lay 6.6-fold (0.82 log units) below the measured number; the measured number lies above the stated range.
By their numbers in this assay, from the lowest: compound 1; then compounds 3 and 2 (each within the scatter of the next); then compound 4.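

In this assay the non-aromatic 1-methylpiperidin-3-yl on a saturated chain carbon bound to an oxygen on an aromatic ring gives the largest step yet seen at this place (a 12-fold higher number from compound 1 to compound 4 (1.06 log units; beyond the scatter)), larger than any step among the three earlier compounds. Among the compounds shown here, the other two steps run the same way and also lie beyond the scatter (a 4.7-fold higher number from compound 3 to compound 4 (0.67 log units; beyond the scatter); a 2.8-fold higher number from compound 2 to compound 4 (0.45 log units; beyond the scatter)), so compound 4 is the weakest inhibitor of the four, and the group at this place can move the number further than the earlier compounds showed. No measured property of these compounds bears on this result, and the size of the change stays unexplained.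

With a single non-aromatic ring in the set, the change cannot be assigned to the loss of the aromatic ring, to the ring nitrogen or to its methyl group. A cyclohexyl group, a piperidin-3-yl group without the methyl and a 1-methylpiperidin-4-yl group at the same place would separate these readings, and a phenyl group would show how much the pyridine nitrogen of compound 1 contributes.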